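A few compounds are considered here, and "the series" means these few. Any claim that something is new, unique, unknown or untested is made for them only; others in the source may bear on it.

In an ADME assay on CEMx174 cells (Homo sapiens) for cytotoxicity (on this read-out higher numbers stand for lower toxicity in this test and lower numbers for higher toxicity in this test), compound 1 (`CC1=C(C(=O)OCc2ccccc2)C(c2cccc(O)c2)NC(=O)N1`) gives > 10000 nM as a limit of the assay and not a number. Compound 2 (`O=C1NC(C2CC2)=C(C(=O)OCC2CCCCC2)C(c2cccc(O)c2)N1`) gives > 10000 nM which is again a limit. Compound 3 (`CCC1=C(C(=O)OCC2CCCCC2)C(c2cccc([N+](=O)[O-])c2)NC(=O)N1`) stands in the same place, with > 10000 nM as a limit too. Compound 4 (`CCC1=C(C(=O)OCC2CCCCC2)C(c2ccc(NC)cc2)NC(=O)N1`) carries 4-(methylamino)phenyl in place of 3-nitrophenyl on a saturated ring carbon. Within the data shown here, no measured pair yet shows what a change of this kind does in this assay so the size of the step rests on little. The expected step (a number no higher from compound 3 to compound 4 (the limit leaves the size open)) is none beyond the scatter, because of the limit of > 10000 nM in this assay, at which 3 of the 3 values shown sit, and it has no expected direction. For compound 4 the estimate is 10000 nM with an expected range from 3000 nM to 30000 nM on this read-out.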

Compound 4, half-maximal cytotoxic concentration: > 10000 nM
Compound 4: no number, only a limit; the forecaster's own chance of this, stated with the estimate: 75%; the middle value lies on the limit itself.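

Among these compounds, no step from compound 3 to compound 4 can be read in this assay because both values are limits and not numbers: the limit of > 10000 nM in this assay, at which 4 of the 4 values shown sit. The compounds shown leave open how far each lies from that limit, and what 4-(methylamino)phenyl in place of 3-nitrophenyl does to the read-out.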